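Longer Ester Chain on a Phenolic Amide Scaffold

A few compounds are considered here, and "the series" means these few. Any claim that something is new, unique, unknown or untested is made for them only; others in the source may bear on it.

For the measured compounds named here, in an assay on SH-SY5Y cells for agonist activity at transient receptor potential cation channel subfamily V member 1 (Homo sapiens), read by fluorescence and calcium flux, with a stated time of 25 min (a higher number here means that more compound is needed for the effect, a lower number that less compound is needed), compound 1 `CCCCCCCC(=O)OCC(=O)NCc1ccc(O)c(OC)c1` gives 40 nM, the lowest of the three numbers measured so far. Compound 2 `COc1cc(CNC(=O)COC(=O)/C=C(\C)CCC=C(C)C)ccc1O` gives 140 nM, and compound 3 `CCCCCCCCCC(=O)OCC(=O)NCc1ccc(O)c(OC)c1` gives 200 nM. Compound 4 `CCCCCCCCCCCC(=O)OCC(=O)NCc1ccc(O)c(OC)c1` has not yet been measured; it differs from compound 1 by butyl in place of hydrogen on a saturated chain carbon, seven bonds along the chain from a carbonyl carbon. Going by the values given here, the one measured step that bears on this change is a 5.0-fold higher number from compound 1 to compound 3 (0.70 log units; beyond the scatter), where the same saturated chain was extended at the same place, but by a shorter piece. Extending the chain further in compound 4 is therefore expected to raise the number again, probably by at least as much. In this assay the estimate for compound 4 is 700 nM, within 200 nM to 2500 nM, which means an expected step of an 18-fold higher number from compound 1 to compound 4 (1.24 log units; beyond the scatter).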

Compound 4, half-maximal effective concentration: 370 nM
Estimate against measurement, compound 4: 1.9-fold (0.28 log units) above; the range from low to high includes it.
By their numbers in this assay, from the lowest: compound 1; then compounds 2, 3 and 4 (each within the scatter of the next, the first and the last beyond it).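

In this assay the higher number seen with the shorter extension also holds for butyl in place of hydrogen (a 9.3-fold higher number from compound 1 to compound 4 (0.97 log units; beyond the scatter)). The further ethyl, nine bonds along the chain from a carbonyl carbon, adds nothing that can be told from the scatter (a 1.9-fold higher number from compound 3 to compound 4 (0.27 log units; within the scatter)). Nothing measured here accounts for these steps.

On these data alone, whether a still longer chain would stay level with these two or move the number again remains open. So does whether a shorter chain than that of compound 1, or an amine at the chain end, would give a lower number.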